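Acylguanidine series: amide N-methylation step

The source may hold more compounds than are shown below. What is called first, only, known or untested is meant among the compounds shown, and "the series" means these compounds.

compound 1 `CC(=O)/N=C(\N)NCCCc1c[nH]cn1`: 724 nM
compound 2 `N/C(=N\C(=O)CCNC(=O)c1cc2ccccc2[nH]1)NCCCc1c[nH]cn1`: 83.2 nM

In an in vitro assay on Sf9 cells for agonist activity at histamine H2 receptor (Homo sapiens), read by scintillation counting (on this read-out lower numbers stand for an effect already at smaller amounts and higher numbers for an effect only at larger amounts of compound), compound 1 gives 724 nM and compound 2 gives 83.2 nM, the lower of the two numbers, with a gap to compound 1 beyond the scatter. Compound 3 `CN(CCC(=O)/N=C(\N)NCCCc1c[nH]cn1)C(=O)c1cc2ccccc2[nH]1` differs from compound 2 by methyl in place of hydrogen on an amide-type nitrogen. For the measured compounds named here, no measured pair shows this change, so its size is open; a small loss in this assay, at the edge of the scatter, is expected, as a 2.0-fold higher number from compound 2 to compound 3 (0.31 log units; beyond the scatter). Compound 3 is estimated at 170 nM, within 50 nM to 600 nM.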

Compound 3, half-maximal effective concentration: 347 nM
Beside the measured number, compound 3's estimate is 2.0-fold (0.31 log units) below it; low and high end bracket the measured number.
By their numbers in this assay, from the lowest: compound 2; then compound 3; then compound 1.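

In this assay, for the compounds shown here, methyl in place of hydrogen on the amide-type nitrogen gives a 4.2-fold higher number from compound 2 to compound 3 (0.62 log units; beyond the scatter) and so provides the first reading of a change in one place. The amide hydrogen of compound 2 therefore marks a position where adding a single carbon already moves the number beyond the scatter. Nothing available accounts for this loss.

Open, going by these compounds, is whether the step comes from losing the amide hydrogen or from adding the methyl. Also open, on these data alone, is how ethyl or a longer chain on this nitrogen would read.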